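Ring-nitrogen substituent and oral exposure

This account rests on a few compounds, and the source may have more. Where it says the series, first, only, none or still open, it means among the compounds named here.

In an ADME assay on the whole organism for pharmacokinetics, with Rattus norvegicus as the target, at a dose of 5 mg/kg by the oral route (a lower number here means that a smaller share of the oral dose reaches the circulation, a higher number that a larger share of the oral dose reaches the circulation), compound 1 `Cc1nc(-c2nc[nH]n2)ccc1-c1cnc2c(n1)N(C(C)C)C(=O)CN2` gives 64% and compound 2 `COCCN1C(=O)CNc2ncc(-c3ccc(-c4nc[nH]n4)nc3C)nc21` gives 100%, the highest of the two numbers. Compound 3 `CO[C@H]1CC[C@H](N2C(=O)CNc3ncc(-c4ccc(-c5nc[nH]n5)nc4C)nc32)CC1` differs from compound 2 by 4-methoxycyclohexyl in place of 2-methoxyethyl on an amide-type nitrogen in a ring. Among the measured compounds shown here, the only measured step at this place is a number 36 percentage points higher from compound 1 to compound 2 (beyond the scatter), which is large and beyond the scatter. For the measured compounds named here, no measured compound carries a ring at this place. With compound 2 already at 100%, a fall is the expected direction, estimated as a number 28 percentage points lower from compound 2 to compound 3 (beyond the scatter). For compound 3 the estimated value is 72%, with an expected range of 42% to 100%.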

Compound 3, oral bioavailability: 49%
Estimate against measurement, compound 3: 23 percentage points above; the range from low to high includes it.
By their numbers in this assay, from the lowest: compound 3; then compound 1; then compound 2.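

In this assay, a methoxy group on this amide-type nitrogen does not by itself keep the number high: 4-methoxycyclohexyl in place of 2-methoxyethyl gives a number 51 percentage points lower from compound 2 to compound 3 (beyond the scatter). The ring-bearing group also falls short of plain isopropyl, with a number 15 percentage points lower from compound 1 to compound 3 (beyond the scatter), so the gain seen with the open 2-methoxyethyl chain does not carry over to this group. No available evidence bears on the origin of these differences.

Open, from the compounds shown here alone, is whether the drop follows the ring or its methoxy group, a question that plain cyclohexyl would address. Also open, going by these compounds, is whether a longer chain such as 3-methoxypropyl, or an amine such as 2-aminoethyl, would stay near compound 2.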